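The source may hold more compounds than are shown below. What is called first, only, known or untested is meant among the compounds shown, and "the series" means these compounds.

Compound 3 `COc1ccc2c(=O)oc(-c3ccccc3I)nc2c1` was tested in an assay on isolated protein for inhibition of complement C1r subcomponent (Homo sapiens); on this read-out higher numbers stand for weaker inhibition and lower numbers for stronger inhibition. In this assay compound 3 gives > 62500 nM, which is a limit of the assay and not a number. Compound 1 `O=c1oc(-c2ccccc2I)nc2cc(Cl)ccc12` also gives a limit in this assay, namely > 62500 nM. Compound 2 `Cc1ccc2c(=O)oc(-c3ccccc3I)nc2c1` likewise gives a limit in this assay, namely > 62500 nM. This is the limit of > 62500 nM in this assay, at which 3 of the 3 values shown sit. The measured steps a step that the two limits leave unreadable from compound 1 to compound 2, a step that the two limits leave unreadable from compound 1 to compound 3 and a step that the two limits leave unreadable from compound 2 to compound 3 therefore cannot be read in size or direction. Compound 4 `O=c1oc(-c2ccccc2I)nc2cc([N+](=O)[O-])ccc12` differs from compound 3 by nitro in place of methoxy on an aromatic carbon. Among the measured compounds shown here, no measured step bears on this change, since every value shown is a limit. The expected step of a number no higher from compound 3 to compound 4 (the limit leaves the size open) is none beyond the scatter. Compound 4 is expected to give 62500 nM in this assay, with a range from 20000 nM to 200000 nM, most likely again as a limit.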

Compound 4, half-maximal inhibitory concentration: > 62500 nM
Compound 4 gave a limit, no number; the forecaster's own chance of this, stated with the estimate: 85%; the middle value lies on the limit itself.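

The steps from compound 1, compound 2 and compound 3 to compound 4 cannot be read, since all four compounds give a limit and no number: the limit of > 62500 nM in this assay, at which 4 of the 4 values shown sit. The compounds shown leave open how strongly any of them inhibits in this assay, and whether chloro, methyl, methoxy or nitro makes any difference.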